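Two limits and one open benzyl swap

The source may hold more compounds than are shown below. What is called first, only, known or untested is meant among the compounds shown, and "the series" means these compounds.

Measured in a physicochemical assay for solubility, using the shake flask method, in simulated intestinal fluid, measured as kinetic solubility, with a stated time of 2 h, at 25 degrees C, at pH 6.5; a lower number here means a less soluble compound, a higher number a more soluble compound:
- compound 1 `Cc1noc(-c2nc(C)c3c(c2N)C(=O)N(Cc2ccc(Br)cc2)C3=O)n1`: < 5000 nM
- compound 2 `COc1cccc(CN2C(=O)c3c(C)nc(-c4nc(C)no4)c(N)c3C2=O)c1`: < 5000 nM

Neither entry is a true number. Compound 2 gives < 5000 nM, which is a limit. Compound 1 gives < 5000 nM, which is also a limit. The whole picture so far is the limit of < 5000 nM in this assay, at which 2 of the 2 values shown sit.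

Compound 3 `Cc1noc(-c2nc(C)c3c(c2N)C(=O)N(Cc2ccccc2Cl)C3=O)n1` changes one place, on a saturated chain carbon bound to an amide-type nitrogen in a ring: 2-chlorophenyl in place of 3-methoxyphenyl on a saturated chain carbon bound to an amide-type nitrogen in a ring. Among the measured compounds shown here, the only measured step at that place is a step that the two limits leave unreadable from compound 1 to compound 2, so it offers no size to carry over. With no readable step to go on, no shift beyond the scatter is expected, and no direction can be given. The estimated step is a step that the limit leaves unreadable from compound 2 to compound 3. For compound 3, the expected value in this assay is 2500 nM, with an estimated range from 800 nM to 5000 nM.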

Compound 3, solubility: < 5000 nM
Compound 3 gave a limit, no number; the forecaster's own chance of this, stated with the estimate: 85%; the middle value lies beyond the limit too.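

In this assay, among the compounds shown here, compound 3 gives a limit, not a number, so no step among compound 1, compound 2 and compound 3 can be read. Still open is how soluble each compound truly is, and whether swapping 4-bromophenyl, 3-methoxyphenyl and 2-chlorophenyl changes that at all, with everything resting on one reading: the limit of < 5000 nM in this assay, at which 3 of the 3 values shown sit.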